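This account rests on a few compounds, and the source may have more. Where it says the series, first, only, none or still open, it means among the compounds named here.

Measured so far:
compound 1, `OC(COc1ccnc2cc(C(F)(F)F)ccc12)CN1CCN(C(c2ccccc2)c2ccccc2)CC1` — in a functional assay (heart) with Rattus norvegicus as the target (on this read-out lower numbers stand for an effect already at smaller amounts and higher numbers for an effect only at larger amounts of compound), compound 1 gives 400 nM
compound 2, `OC(COc1cccc2cnccc12)CN1CCN(C(c2ccccc2)c2ccccc2)CC1` — in this assay compound 2 gives 1500 nM

Of the two numbers shown, compound 2 stands at the higher one; compound 1, its nearest neighbour, sits well apart from it, beyond the usual scatter. Compound 3, `OC(COc1ccc2cccnc2c1)CN1CCN(C(c2ccccc2)c2ccccc2)CC1`, has not yet been measured in this assay. It is built from the same atoms as compound 2, joined differently: quinolin-7-yl in place of isoquinolin-5-yl on an oxygen on a saturated carbon. Among the measured compounds shown here, no measured pair shows what such a rearrangement of the ring nitrogen does here, so the size of the step has to be guessed. With nothing to rest on but the value of compound 2, the expectation is for no step beyond the scatter, with a wide margin in either direction. The expected step of a 1.3-fold lower number from compound 2 to compound 3 (0.10 log units; within the scatter) is therefore small. Compound 3 is estimated at 1200 nM in this assay, within 400 nM to 4000 nM.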

Compound 3, half-maximal effective concentration: 1010 nM
Beside the measured number, compound 3's estimate is 1.2-fold (0.07 log units) above it, within the range that was stated.
By their numbers in this assay, from the lowest: compound 1; then compounds 3 and 2 (each within the scatter of the next).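

Quinolin-7-yl in place of isoquinolin-5-yl on an oxygen on a saturated carbon gives a 1.5-fold lower number from compound 2 to compound 3 (0.17 log units; within the scatter) in this assay, the first direct reading of such a rearrangement in this series. With the same atoms joined differently, this position therefore shows no difference beyond the scatter between these two groups, so this read-out does not separate them. Nothing on hand accounts for this result.

Compound 1 differs from both compounds in more than one place, so the compounds shown do not tie its lower number to any single change. Also open, as far as these compounds go, is whether adding an amine or a methoxy group to quinolin-7-yl, or replacing that group with a plain phenyl ring, would shift the number beyond the scatter.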